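From Methyl to Dimethylamino: Estimating Compound 3

The compounds below may be only part of what the source reports. "The series", "measured", "known", "first", "only" and "open" are said of these compounds alone.

Measured so far in a physicochemical assay for solubility, read by HPLC, in phosphate buffer, with a stated time of 24 h, at pH 7.4, tested at 100 uM; on this read-out lower numbers stand for lower solubility and higher numbers for higher solubility:
- compound 1 `O=C(CCCCCNc1c(Nc2ccccc2)c(=O)c1=O)NO` gives 47000000 nM
- compound 2 `Cc1ccc(Nc2c(NCCCCCC(=O)NO)c(=O)c2=O)cc1` gives 8100000 nM

Of these two numbers, compound 2 holds the lower one, and compound 1 stands above it. Compound 3 `CN(C)c1ccc(Nc2c(NCCCCCC(=O)NO)c(=O)c2=O)cc1` has not yet been measured. It differs from compound 2 by a single change, dimethylamino in place of methyl on an aromatic carbon. Among the compounds with values here, only one measured step bears on this: a 5.8-fold lower number from compound 1 to compound 2 (0.76 log units; beyond the scatter). That modest step came with methyl in place of hydrogen on an aromatic carbon, which is a different swap at an aromatic carbon and so only a weak guide. In this assay a slightly lower number is therefore expected, with no shift beyond the scatter. The expected change is a 1.4-fold lower number from compound 2 to compound 3 (0.13 log units; within the scatter). For compound 3 the estimated value is 6000000 nM, with an expected range from 1500000 nM to 25000000 nM.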

Compound 3, solubility: 12000000 nM
Compound 3: the middle estimate sits 2.0-fold (0.30 log units) below what was measured, and the stated range covers the measured number.
By their numbers in this assay, from the lowest: compounds 2 and 3 (each within the scatter of the next); then compound 1.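

In this assay, dimethylamino in place of methyl on this aromatic carbon, para to a large group, gives a 1.5-fold higher number from compound 2 to compound 3 (0.17 log units; within the scatter), so the two groups cannot be told apart on this read-out. Set against hydrogen at the same carbon, dimethylamino gives a 3.9-fold lower number from compound 1 to compound 3 (0.59 log units; beyond the scatter), so the gap from hydrogen is no longer seen with methyl alone: in these three compounds, both groups at this carbon give numbers beyond the scatter from the hydrogen compound. No measurement at hand gives a reason for these numbers.

Still open, as far as these compounds go, is whether a carboxylic acid or a fluorine at this same carbon would also stay within the scatter of compound 2 or would move the number further from compound 1. The compounds shown also leave open whether these steps keep their size on a core with a longer chain.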